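Chloro on the anilino ring, tried a second time

A few compounds are considered here, and "the series" means these few. Any claim that something is new, unique, unknown or untested is made for them only; others in the source may bear on it.

Three measured compounds share one core. Compound 1 `N#Cc1c(Nc2ccccc2)nc(SCC(=O)Nn2c(COc3ccc(Cl)cc3Cl)nc3ccccc3c2=O)nc1-c1ccc(Cl)cc1` gives 56.1% in a functional assay on the whole organism (strain albino) for inhibition, with Rattus norvegicus as the target, read by paw edema, with stated times of 1 h and 3 h, at a dose of 100 mg/kg by the oral route; a lower number here means a weaker effect, a higher number a stronger effect of the compound at the dose given. Compound 2 `N#Cc1c(Nc2ccc(Cl)cc2)nc(SCC(=O)Nn2c(COc3ccc(Cl)cc3Cl)nc3ccccc3c2=O)nc1-c1ccc(Cl)cc1` differs from it by chloro in place of hydrogen on an aromatic carbon; this change made a number 8.8 percentage points higher from compound 1 to compound 2 (within the scatter). Compound 3 `N#Cc1c(Nc2ccccc2)nc(SCC(=O)Nn2c(COc3ccc(Cl)cc3Cl)nc3ccccc3c2=O)nc1-c1ccc(O)cc1` differs from compound 1 by hydroxy in place of chloro on an aromatic carbon, and in this assay compound 3 gives 91.2%, the highest of the three, while compound 2 gives 64.9%.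

Compound 4 `N#Cc1c(Nc2ccc(Cl)cc2)nc(SCC(=O)Nn2c(COc3ccc(Cl)cc3Cl)nc3ccccc3c2=O)nc1-c1ccc(O)cc1` has not yet been measured. It differs from compound 3 by chloro in place of hydrogen on an aromatic carbon, which is the same change as that from compound 1 to compound 2, made on the core of compound 3 instead. That earlier step was within the scatter, and compound 3 already stands close to full inhibition, so the step from compound 3 to compound 4 is expected to be small, about a number 1.8 percentage points higher from compound 3 to compound 4 (within the scatter) in this assay. On that basis compound 4 is estimated to give 93% in this assay, most likely between 84% and 99%.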

Compound 4, a percentage reported as inhibition, in the whole organism at one dose (the size of the read-out at that dose, not a potency): 79%
Compound 4: middle estimate off by 14 percentage points, on the high side; the whole stated range lies above it.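

In this assay, chloro on the anilino ring gave a number 12.2 percentage points lower from compound 3 to compound 4 (beyond the scatter), so on the core of compound 3 the same change does not repeat its result from the core of compound 1: the same change on two cores in this assay, a number 8.8 percentage points higher (within the scatter) from compound 1 to compound 2 and a number 12.2 percentage points lower (beyond the scatter) from compound 3 to compound 4, 21 percentage points apart, beyond the scatter of two such steps

The hydroxy in place of chloro also raises the number on both cores, but here it gave a number 14.1 percentage points higher from compound 2 to compound 4 (beyond the scatter), and its size depends on the core: the same change on two cores in this assay, a number 35.1 percentage points higher (beyond the scatter) from compound 1 to compound 3 and a number 14.1 percentage points higher (beyond the scatter) from compound 2 to compound 4, 21 percentage points apart, beyond the scatter of two such steps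

These four compounds show that, in this assay and at this one dose, the two changes do not simply add up, but they do not show why, nor how either change would behave on any other core.

The compounds shown leave open whether a methoxy or an amine in the place of the hydroxy would keep the higher numbers. They also leave open whether a fluoro or a methyl on the anilino ring would follow the chloro on these two cores.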